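Swapping the benzyl arm for a piperidinylpropyl chain

The compounds below may be only part of what the source reports. "The series", "measured", "known", "first", "only" and "open" are said of these compounds alone.

Of the compounds shown here, three have so far been measured in an assay on HEK293 cells for inhibition of Steryl-sulfatase (Homo sapiens), tested at 0.1 uM; on this read-out lower numbers stand for a weaker effect and higher numbers for a stronger effect at the one concentration tested.

Compound 1 `CCN(Cc1ccccn1)c1ccc(C(=O)N2CCc3ccc(OS(N)(=O)=O)cc3C2)cc1` gives 42.5%.
Compound 2 `CCN(Cc1ccc(Br)cc1)c1ccc(C(=O)N2CCc3ccc(OS(N)(=O)=O)cc3C2)cc1` gives 78.2%.
Compound 3 `CCN(Cc1ccccc1)c1ccc(C(=O)N2CCc3ccc(OS(N)(=O)=O)cc3C2)cc1` gives 66.9%.

Compound 3 stands second highest of the three: the step of a number 11.3 percentage points lower from compound 2 to compound 3 (beyond the scatter) separates it from the highest number, and the step of a number 24.4 percentage points higher from compound 1 to compound 3 (beyond the scatter) from the lowest. Compound 4 `CN(CCCN1CCCCC1)c1ccc(C(=O)N2CCc3ccc(OS(N)(=O)=O)cc3C2)cc1` differs from it by methyl(3-(piperidin-1-yl)propyl)amino in place of benzyl(ethyl)amino on an aromatic carbon.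

Going by the values given here, none of the measured steps touches this exchange directly. All three alter only the aromatic ring on the saturated chain carbon bound to the nitrogen: a number 35.7 percentage points higher from compound 1 to compound 2 (beyond the scatter) was large, a number 24.4 percentage points higher from compound 1 to compound 3 (beyond the scatter) modest, and a number 11.3 percentage points lower from compound 2 to compound 3 (beyond the scatter) modest. Those steps show that this part of the molecule moves the read-out well beyond the scatter, but they say nothing about removing the aromatic ring altogether in favour of a methyl(3-(piperidin-1-yl)propyl)amino group. The author therefore expects a step of a number 21.9 percentage points lower from compound 3 to compound 4 (beyond the scatter), downward but with a wide band of doubt. Compound 4 is estimated at 45%, within a range from 15% to 75%.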

Compound 4, a percentage reported as inhibition, at one concentration (the size of the read-out at that concentration, not a potency): 17.4%
The estimate for compound 4 lay 27.6 percentage points above the measured number; measured number inside the range.
By their numbers in this assay, from the lowest: compound 4; then compound 1; then compound 3; then compound 2.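

In this assay, going by these compounds alone, the earlier compounds varied only the aromatic ring of the arm, whereas this exchange replaces the whole amino group on the aromatic carbon and gives a number 49.5 percentage points lower from compound 3 to compound 4 (beyond the scatter) and a number 60.8 percentage points lower from compound 2 to compound 4 (beyond the scatter) and a number 25.1 percentage points lower from compound 1 to compound 4 (beyond the scatter). Compound 4 therefore holds the lowest number of the four, so methyl(3-(piperidin-1-yl)propyl)amino falls below even the pyridin-2-yl arm, previously the lowest, and the position proves sensitive to more than the choice of aromatic ring. No measurement is available that would explain this drop.

The exchange alters the ring, the chain and the small alkyl group on the nitrogen at once, and the compounds shown cannot separate these changes. Going by these compounds, it remains open whether a cyclohexylmethyl arm, a 3-phenylpropyl chain or a 3-cyclohexylpropyl chain would keep the number closer to that of compound 3.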